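The compounds below may be only part of what the source reports. "The series", "measured", "known", "first", "only" and "open" are said of these compounds alone.

Measured in an ADME assay on K562 cells (Homo sapiens) for cytotoxicity, read by MTT assay, with a stated time of 5 days; a higher number here means a weaker inhibitor, a lower number a stronger inhibitor:
compound 1 `COc1ccc(/C=C(\C#N)C(=O)c2cc(OC)c(OC)c(OC)c2)cc1O`: 4200 nM
compound 2 `COc1cc(C(=O)/C(C#N)=C/c2ccc(C(F)(F)F)cc2)cc(OC)c1OC`: > 10000 nM (a limit)

Within the data shown here, compound 1 holds the only numeric value so far, so it has no measured neighbour to be ranked against. Compound 2 gives > 10000 nM, which is a limit of the assay and not a number.

Next in line is compound 3 `COc1ccc(/C=C(\C#N)C(=O)c2cc(OC)c(OC)c(OC)c2)cc1Br`, which keeps the core of compound 1 and changes one place: bromo in place of hydroxy on an aromatic carbon. This is bromo in place of hydroxy on an aromatic carbon, ortho to a methoxy group, turning 3-hydroxy-4-methoxyphenyl into 3-bromo-4-methoxyphenyl.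

Among the measured compounds shown here, no measured pair isolates a single change, so the size of the step in this assay has no direct support. The estimate therefore starts from compound 1 at 4200 nM, and a small weakening is expected, possibly none beyond the scatter. The expected change is a 1.2-fold higher number from compound 1 to compound 3 (0.08 log units; within the scatter). Compound 3 is estimated at 5000 nM. The expected range for compound 3 runs from 1500 nM to 10000 nM.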

Compound 3, half-maximal inhibitory concentration: > 10000 nM
Compound 3: a limit, no number; the forecaster's own chance of this, stated with the estimate: 25%; middle value at least 2.0-fold (0.30 log units) away from the limit.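

Among these compounds, this is the first step that isolates a single place: in this assay, bromo in place of hydroxy gives an at least 2.3-fold higher number from compound 1 to compound 3 (0.37 log units; beyond the scatter). The position on the aromatic carbon ortho to a methoxy group is therefore not indifferent to this exchange, and 3-bromo-4-methoxyphenyl does not retain the measurable activity of 3-hydroxy-4-methoxyphenyl in this assay. Compound 3 gives > 10000 nM, which is a limit and not a number, so the step marks only a lower bound and its full size stays unread: the limit of > 10000 nM in this assay, at which 2 of the 3 values shown sit.

The compounds shown do not separate loss of the hydroxy from entry of the bromo, as this single exchange changes both at once. An amino group or a fluoro group at the same place, on the core of compound 1, would show whether any replacement of the hydroxy carries a similar step or whether the outcome is specific to bromo.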